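This account rests on a few compounds, and the source may have more. Where it says the series, first, only, none or still open, it means among the compounds named here.

Working notes on the series. The shared core appears in compound 1 `O=C1Nc2ccccc2/C1=C\c1c(Cl)n(Cc2ccccc2)c2ccccc12` and in compound 2 `O=C1Nc2ccccc2/C1=C\c1c(Cl)n(CCCc2ccccc2)c2ccccc12`. In a functional assay on NSCLC cells (Homo sapiens) for cytotoxicity, with a stated time of 48 h (on this read-out lower numbers stand for stronger inhibition of growth and higher numbers for weaker inhibition of growth), compound 1 gives 57500 nM, and in this assay compound 2 gives 72400 nM. Among the measured compounds shown here, the one step measured so far, a 1.3-fold higher number from compound 1 to compound 2 (0.10 log units; within the scatter), leaves the two compounds within the scatter of each other, so compound 2 stands at a number that is not separated from that of compound 1; with only two compounds in hand, nothing can be said about an order.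

Compound 3 `O=C1Nc2ccc(Cl)cc2/C1=C\c1c(Cl)n(CCCc2ccccc2)c2ccccc12` is the next entry. It differs from compound 2 by chloro in place of hydrogen on an aromatic carbon. For the measured compounds named here, no measured pair carries such a change on the core; the single step available, a 1.3-fold higher number from compound 1 to compound 2 (0.10 log units; within the scatter), concerns the chain on the aromatic nitrogen and does not inform a substituent on the core. In the absence of any bearing step, the expectation for compound 3 in this assay is a step no larger than the scatter, a 1.0-fold lower number from compound 2 to compound 3 (0.01 log units; within the scatter). Compound 3 is therefore estimated at 70000 nM, with a range from 25000 nM to 200000 nM.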

Compound 3, concentration for total growth inhibition: 8910 nM
For compound 3 the middle estimate is 7.9-fold (0.90 log units) above the measured one, outside the stated range (below it).
By their numbers in this assay, from the lowest: compound 3; then compounds 1 and 2 (each within the scatter of the next).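

Among the compounds shown here, compound 3 provides the first measured change on the shared core rather than on the chain on the aromatic nitrogen: in this assay, chloro in place of hydrogen on an aromatic carbon gives an 8.1-fold lower number from compound 2 to compound 3 (0.91 log units; beyond the scatter), whereas the chain change gave a 1.3-fold higher number from compound 1 to compound 2 (0.10 log units; within the scatter). This position, on a six-membered aromatic ring of carbon only that is part of a fused or bridged system of two rings, is therefore one where the entry of a single chlorine atom moves the number beyond the scatter, so the core responds here in a way the chain step gave no sign of. No measurement in hand accounts for the size of this step.

From the compounds shown here alone, it remains open whether the step is particular to chloro or would also appear with fluoro, methoxy or an amine at the same carbon, and whether chloro on the other aromatic carbons of the core would give a similar step. Going by these compounds, it is also open whether chloro here would give a step of this size on the chain of compound 1.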